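Methyl for chloro on the anilino ring of compound 1

The compounds below may be only part of what the source reports. "The series", "measured", "known", "first", "only" and "open" are said of these compounds alone.

Compound 1 `Fc1cccc(-c2nc(Nc3ccc(Cl)cc3)c3cc(F)ccc3n2)c1` is known only as a limit: in a functional assay on MDA-MB-231 cells (Homo sapiens) for cytotoxicity, read by MTT assay, with a stated time of 48 h (a lower number here means a stronger inhibitor, a higher number a weaker inhibitor), compound 1 gives > 50000 nM. Compound 2 `Fc1cccc(-c2nc(Nc3cccc(Cl)c3)c3cc(F)ccc3n2)c1` is likewise only a limit, giving in this assay > 50000 nM. Among the measured compounds shown here, the single measured step, a step that the two limits leave unreadable from compound 1 to compound 2, therefore cannot be sized; all that stands is the limit of > 50000 nM in this assay, at which 2 of the 2 values shown sit. Compound 3 `Cc1ccc(Nc2nc(-c3cccc(F)c3)nc3ccc(F)cc23)cc1` carries methyl in place of chloro on an aromatic carbon. For the measured compounds named here, no measured step bears on this change, so no shift beyond the scatter is expected. Compound 3 is expected near 80000 nM, within 25000 nM to 300000 nM, most likely again reported only as a limit. The expected step that the limit leaves unreadable from compound 1 to compound 3 is essentially nil.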

Compound 3, half-maximal inhibitory concentration: > 50000 nM
Compound 3 gave a limit, no number (the forecaster's own chance of this, stated with the estimate: 75%); the middle value lies beyond the limit too.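

Among the compounds shown here, compound 1, compound 2 and compound 3 all stand as limits, so no step among them can be read: the limit of > 50000 nM in this assay, at which 3 of the 3 values shown sit.
In this assay the compounds shown leave open whether the anilino substituent, chloro or methyl, affects cytotoxicity at all.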